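The source may report more compounds than this note shows. Statements on the series, on what has been measured and on what is new or still open speak of the compounds shown alone.

Working notes on the shared core. In a functional assay on RT-112 cells (Homo sapiens) for antiproliferative activity, read by MTT assay, with a stated time of 72 h (a lower number here means a stronger inhibitor of growth, a higher number a weaker inhibitor of growth), compound 1 `COc1cc(Nc2ncnc3c(NC(=O)Nc4cc(C(F)(F)F)cc(C(F)(F)F)c4)cccc23)cc(OC)c1` gives 467 nM. Compound 2 `COc1cc(Nc2ncnc3c(NC(=O)Nc4ccc([N+](=O)[O-])cc4)cccc23)cc(OC)c1` gives only a limit of this assay, > 20000 nM, not a number. Compound 3 `COc1cc(Nc2ncnc3c(NC(=O)Nc4ccc(C(F)(F)F)cc4[N+](=O)[O-])cccc23)cc(OC)c1` likewise stops at a limit in this assay, > 20000 nM. Compound 2 therefore stands at the limit of > 20000 nM in this assay, at which 2 of the 3 values shown sit, the weak end of what has been measured so far, with no number to anchor it. Compound 4 `COc1cc(Nc2ncnc3c(NC(=O)c4cc(=O)c5ccccc5o4)cccc23)cc(OC)c1` is not yet measured. It differs from compound 2 by a group of 11 heavy atoms (9 carbon, 2 oxygen; one six-membered aromatic ring of carbon only, one six-membered aromatic ring with 1 hetero atom) in place of a group of 10 heavy atoms (6 carbon, 2 nitrogen, 2 oxygen; one six-membered aromatic ring of carbon only), on a carbonyl carbon. No measured step connects any pair of these compounds, so the size of this change is open; the expected step, an at least 3.3-fold lower number from compound 2 to compound 4 (0.52 log units; beyond the scatter), points toward stronger inhibition but with wide uncertainty. Compound 4 is estimated at 6000 nM, in the range 1500 nM to 20000 nM.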

Compound 4, concentration for 50% growth inhibition: > 20000 nM
Compound 4: only a limit was reported; the forecaster's own chance of this, stated with the estimate: 40%; middle value at least 3.3-fold (0.52 log units) away from the limit.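

In this assay, going by these compounds alone, compound 2 and compound 4 both stop at a limit, so no step between them can be read. Left open is whether replacing the (4-nitrophenyl)amino group of compound 2 with the group on the carbonyl carbon of compound 4 shifts growth inhibition at all.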